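A few compounds are considered here, and "the series" means these few. Any claim that something is new, unique, unknown or untested is made for them only; others in the source may bear on it.

Measured compounds: compound 1 `CN1CCN(CCCS(=O)(=O)c2ccc3nc(NC(=O)NC(=O)c4cc(-n5cccn5)ccc4Cl)sc3c2)CC1` gives 0.67 nM in an assay on HEK293 cells for displacement of a labelled ligand from growth hormone secretagogue receptor type 1 (Homo sapiens), with a stated time of 60 min; a higher number here means a weaker inhibitor, a lower number a stronger inhibitor; compound 2 `CN1CCC(S(=O)(=O)c2ccc3nc(NC(=O)NC(=O)c4cc(N5CCCC5)ccc4Cl)sc3c2)CC1` gives 0.92 nM; compound 3 `CN1CCC(S(=O)(=O)c2ccc3nc(NC(=O)NC(=O)c4cc(-n5cccn5)ccc4Cl)sc3c2)CC1` gives 15 nM.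

Compound 3 stands highest of the three numbers in this assay, so it is the weakest inhibitor shown; the nearest is compound 2, a step of a 16-fold higher number from compound 2 to compound 3 (1.21 log units; beyond the scatter), and the furthest is compound 1, a step of a 22-fold higher number from compound 1 to compound 3 (1.35 log units; beyond the scatter). Compound 4 `CN1CCC(S(=O)(=O)c2ccc3nc(NC(=O)NC(=O)c4cc5c(cc4Cl)CCN5C)sc3c2)CC1` differs from compound 3 in one place: 5-chloro-1-methyl-2,3-dihydro-1H-indol-6-yl in place of 2-chloro-5-(1H-pyrazol-1-yl)phenyl on a carbonyl carbon. The step that bears on this is a 16-fold higher number from compound 2 to compound 3 (1.21 log units; beyond the scatter), where a five-membered non-aromatic nitrogen ring was exchanged for an aromatic one and the number rose sharply. Compound 4 brings back a five-membered non-aromatic ring with one hetero atom, now fused to the phenyl, so a step back toward lower numbers is expected: a 7.5-fold lower number from compound 3 to compound 4 (0.88 log units; beyond the scatter). Compound 4 is therefore estimated at 2 nM, within 0.5 nM to 8 nM.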

Compound 4, half-maximal inhibitory concentration: 7.2 nM
Beside the measured number, compound 4's estimate is 3.6-fold (0.56 log units) below it; the range from low to high includes it.
By their numbers in this assay, from the lowest: compounds 1 and 2 (each within the scatter of the next); then compound 4; then compound 3.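

On the carbonyl carbon, 5-chloro-1-methyl-2,3-dihydro-1H-indol-6-yl gives a 2.1-fold lower number from compound 3 to compound 4 (0.32 log units; beyond the scatter) against the pyrazole-bearing group, yet a 7.8-fold higher number from compound 2 to compound 4 (0.89 log units; beyond the scatter) against the pyrrolidine-bearing group. A non-aromatic ring with one nitrogen, fused to the phenyl, therefore recovers only part of the gap, so having such a ring is not enough to reach the number of compound 2. No measurement here explains why the fused ring and the pyrrolidine ring differ.

As far as these compounds go, it remains open whether a piperidine or morpholine ring in place of the pyrrolidine would keep the low number. Also open, from the compounds shown here alone, is whether 3-(4-methylpiperazin-1-yl)propyl on the sulfonyl sulfur would lower the number of compound 4.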